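The source may report more compounds than this note shows. Statements on the series, on what has been measured and on what is new or still open speak of the compounds shown alone.

Of the compounds shown here, two have been measured in a functional assay on MT2 cells (Homo sapiens) for cytotoxicity, read by MTT assay; on this read-out lower numbers stand for higher toxicity in this test and higher numbers for lower toxicity in this test. Compound 1 `CC(C)=CCOc1cccc(Nc2ncccn2)c1` returns only a limit, > 100000 nM. Compound 2 `CC(C)=CCOc1cc(Nc2ncccn2)ccc1C` gives 78000 nM in this assay. Going by the values given here, the one step between measured compounds, an at least 1.2-fold lower number from compound 1 to compound 2 (0.10 log units; that floor lies within the scatter), rests on one side on that limit (the limit of > 100000 nM in this assay, at which 1 of the 2 values shown sits), so its true size is not known. Among the compounds with values here, compound 2 therefore holds the only number in this assay; the other value shown is a limit.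

Compound 3 `CC(C)=CCOc1cc(Nc2ncccn2)ccc1Cl` has not yet been measured in this assay. Its change from compound 2: chloro in place of methyl on an aromatic carbon. Within the data shown here, no measured step exchanges methyl for chloro; the single step known, an at least 1.2-fold lower number from compound 1 to compound 2 (0.10 log units; that floor lies within the scatter), concerns methyl in place of hydrogen and its floor sits within the scatter. Nothing in the series separates the two groups, and no step beyond the scatter is expected in this assay. The expected step is a 1.2-fold lower number from compound 2 to compound 3 (0.08 log units; within the scatter). Compound 3 is expected to give 65000 nM in this assay, with a range from 25000 nM to 150000 nM, and a fair chance that only a limit is returned.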

Compound 3, half-maximal cytotoxic concentration: 2500 nM
The estimate for compound 3 lay 26-fold (1.41 log units) above the measured number; measured number below the stated range.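

In this assay, this position, ortho to a (3-methylbut-2-en-1-yl)oxy group and para to a group of 7 heavy atoms, turns out to respond strongly to the identity of its substituent: exchanging methyl for chloro, one heavy atom for one with no hydrogen-bond donor or acceptor on either side, gives a 31-fold lower number from compound 2 to compound 3 (1.49 log units; beyond the scatter). Methyl there had shown only an at least 1.2-fold lower number from compound 1 to compound 2 (0.10 log units; that floor lies within the scatter), whereas chloro in the same place gives an at least 40-fold lower number from compound 1 to compound 3 (1.60 log units; beyond the scatter), so a clear rise in toxicity in this test appears with chloro and not with methyl. Compound 1 returns only a limit, so the step from hydrogen to chloro is known only as a floor: the limit of > 100000 nM in this assay, at which 1 of the 3 values shown sits.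

The compounds shown do not tell whether the effect belongs to chloro alone or extends to fluoro, bromo, trifluoromethyl or methoxy at this position. They also leave open whether chloro acts the same way at other positions on the ring, and whether it keeps this size of step when the (3-methylbut-2-en-1-yl)oxy group gives way to a shorter chain or an amine.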